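The source may hold more compounds than are shown below. What is called first, only, known or untested is meant among the compounds shown, and "the series" means these compounds.

Measured compounds:
compound 1 `FC(F)(F)c1ccc(-c2ccc3c(NCCCNCc4ccco4)ccnc3c2)cc1`, 237 10^-6 cm/s
compound 2 `COc1ccc(F)cc1CNCCCNc1ccnc2cc(-c3ccc(C(F)(F)F)cc3)ccc12`, 237 10^-6 cm/s
compound 3 `COc1cccc(CNCCCNc2ccnc3cc(-c4ccc(C(F)(F)F)cc4)ccc23)c1O`, 237 10^-6 cm/s

In an ADME assay for permeability, using PAMPA, with a stated time of 30 min, at pH 7.4 (a higher number here means that the compound crosses the layer faster, a lower number that the compound crosses the layer more slowly), compound 1 stands level with compounds 2 and 3. The steps of no change at the digits printed from compound 1 to compound 2 (within the scatter), no change at the digits printed from compound 1 to compound 3 (within the scatter) and no change at the digits printed from compound 2 to compound 3 (within the scatter) all swap the group on a saturated chain carbon bound to an amine nitrogen, and none moves the read-out beyond the scatter.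

Compound 4 `c1coc(CNCCCNc2ccnc3cc(-c4cccc5ccccc45)ccc23)c1` changes a different part of compound 1: naphthalen-1-yl in place of 4-(trifluoromethyl)phenyl on an aromatic carbon. For the measured compounds named here, no measured step touches that position, so the measured steps bear on it only by showing how flat this series is. What leaves and what enters carry neither donor nor acceptor, so no step beyond the scatter is expected for no change at the digits printed from compound 1 to compound 4 (within the scatter). Compound 4 is therefore estimated at 237 10^-6 cm/s, within 120 10^-6 cm/s to 400 10^-6 cm/s.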

Compound 4, apparent permeability: 237 10^-6 cm/s
Estimate against measurement, compound 4: no gap at the digits printed; low and high end bracket the measured number.
By their numbers in this assay, from the lowest: compounds 1, 2, 3 and 4 (each within the scatter of the next).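

Changing the group on this aromatic carbon of a six-membered aromatic ring, with 4-(trifluoromethyl)phenyl leaving and naphthalen-1-yl entering, gives in this assay a step of no change at the digits printed from compound 1 to compound 4 (within the scatter). The flat read-out therefore now extends beyond the saturated chain carbon to a second place on compound 1, and to a swap that removes all the fluorine and brings in a second aromatic ring. Nothing available here gives a reason for this flatness.

Still open, on these data alone, is whether an amine or a carboxylic acid on this same aromatic carbon would move the number. As far as these compounds go, a longer chain in compound 1 remains equally open.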